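Cytotoxicity notes on the shared core series

A few compounds are considered here, and "the series" means these few. Any claim that something is new, unique, unknown or untested is made for them only; others in the source may bear on it.

Measured so far:
- compound 1 `Cc1ccc2[nH]c(=O)c(CN(CCCO)Cc3ccc(C(C)(C)C)cc3)cc2c1`: in a toxicity assay on MDCK cells (Canis lupus familiaris) for cytotoxicity, read by crystal violet staining, with a stated time of 48 h (a lower number here means that less compound is tolerated, a higher number that more compound is tolerated), compound 1 gives > 10000 nM, a limit of the assay.
- compound 2 `Cc1ccc2[nH]c(=O)c(CN(Cc3ccc(C#N)cc3)Cc3ccc(C(C)(C)C)cc3)cc2c1`: in this assay compound 2 gives > 5000 nM, again a limit.

Compound 2 stands only at a limit, namely (the limit of > 5000 nM in this assay, at which 1 of the 2 values shown sits). Going by the values given here, the one measured step, a step that the two limits leave unreadable from compound 1 to compound 2, cannot be read because the limit of > 10000 nM in this assay, at which 1 of the 2 values shown sits, and the limit of > 5000 nM in this assay, at which 1 of the 2 values shown sits, bound both ends. Compound 3 `Cc1ccc2[nH]c(=O)c(CN(Cc3ccc(SC(F)F)cc3)Cc3ccc(C(C)(C)C)cc3)cc2c1` differs from compound 2 by (difluoromethyl)sulfanyl in place of cyano on an aromatic carbon. Among the compounds with values here, no measured step bears on this change. The expected step is a step that the limit leaves unreadable from compound 2 to compound 3, none beyond the scatter. Compound 3 is estimated at 10000 nM, between 3000 nM and 40000 nM, most likely again reported as a limit.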

Compound 3, half-maximal cytotoxic concentration: > 5000 nM
Compound 3: a limit, no number; the forecaster's own chance of this, stated with the estimate: 70%; the middle value does not contradict the limit.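

Compound 3 also stands only at a limit, so no step among compound 1, compound 2 and compound 3 can be read: the limit of > 5000 nM in this assay, at which 2 of the 3 values shown sit.

The compounds shown leave open whether cyano and (difluoromethyl)sulfanyl differ at all in this assay.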